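The source may hold more compounds than are shown below. What is called first, only, known or untested is meant among the compounds shown, and "the series" means these compounds.

Values in a functional assay on BXPC-3 cells (Homo sapiens) for antiproliferative activity, read by MTT assay, with a stated time of 24 h; on this read-out lower numbers stand for stronger inhibition and higher numbers for weaker inhibition:
- compound 1 `CCn1c(C(=O)NCCNC(=O)OC(C)(C)C)ccc1C(CC)(CC)c1ccc(OCS(=O)(=O)c2ccccc2)c(C)c1`: > 50000 nM (a limit of the assay, not a number)
- compound 2 `CCn1c(C(=O)NC2(CO)CC2)ccc1C(CC)(CC)c1ccc(OCS(=O)(=O)c2ccccc2)c(C)c1`: 45400 nM
- compound 3 `CCn1c(C(=O)NCCCO)ccc1C(CC)(CC)c1ccc(OCS(=O)(=O)c2ccccc2)c(C)c1`: 26600 nM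

Within the data shown here, compound 3 stands level with compound 2, the only other number, since a 1.7-fold lower number from compound 2 to compound 3 (0.23 log units; within the scatter) lies within the scatter. The change to compound 4 `CCn1c(C(=O)N[C@@H](CO)CCCO)ccc1C(CC)(CC)c1ccc(OCS(=O)(=O)c2ccccc2)c(C)c1` is a group of 7 heavy atoms (5 carbon, 2 oxygen; no ring) in place of a group of 4 heavy atoms (3 carbon, 1 oxygen; no ring), on an amide-type nitrogen. All measured steps bear on this, as each changes the group on the same amide-type nitrogen. Besides the step above, an at least 1.1-fold lower number from compound 1 to compound 2 (0.04 log units; that floor lies within the scatter) and an at least 1.8-fold lower number from compound 1 to compound 3 (0.27 log units; that floor lies within the scatter) are only floors set by a limit, and both lie within the scatter. No step beyond the scatter is therefore expected in this assay. The expected change is a 1.1-fold higher number from compound 3 to compound 4 (0.02 log units; within the scatter). For compound 4 the estimated value is 28000 nM, with an expected range of 11000 nM to 50000 nM.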

Compound 4, half-maximal inhibitory concentration: 16400 nM
Compound 4: middle estimate off by 1.7-fold (0.23 log units), on the high side, and the stated range covers the measured number.
By their numbers in this assay, from the lowest: compounds 4, 3 and 2 (each within the scatter of the next, the first and the last beyond it). At a limit, above all of these: compound 1.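

In this assay, changing the group on the amide-type nitrogen now gives steps beyond the scatter: a 2.8-fold lower number from compound 2 to compound 4 (0.44 log units; beyond the scatter), and an at least 3.0-fold lower number from compound 1 to compound 4 (0.48 log units; beyond the scatter). The new group, with its defined stereocentre, is not separated from 3-hydroxypropyl, since the remaining step lies within the scatter: a 1.6-fold lower number from compound 3 to compound 4 (0.21 log units; within the scatter). The step from compound 1 is only a floor, as compound 1 stands at a limit: the limit of > 50000 nM in this assay, at which 1 of the 4 values shown sits.

Open questions are whether the opposite configuration at the stereocentre gives a similar number, and whether an amine or a carboxylic acid in place of a terminal hydroxyl moves the number further.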